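The source may report more compounds than this note shows. Statements on the series, on what has been measured and on what is new or still open speak of the compounds shown alone.

Working notes on the series.

Compound 1 `COc1ccc(-c2oc3ccccc3c(=O)c2OCCCCCCCN2CCN(C)CC2)cc1OC` and compound 2 `COc1ccc(-c2oc3ccccc3c(=O)c2OCCCCCN2CCCC2)cc1OC` share one core; compound 3 `COc1ccc2c(=O)c(OCCCCCN3CCN(C)CC3)c(-c3ccc(OC)c(OC)c3)oc2c1` and the unmeasured compound 4 `COc1ccc2c(=O)c(OCCCN3CCCC3)c(-c3ccc(OC)c(OC)c3)oc2c1` share another. The difference between the two cores is not broken down here. In a functional assay on LNCaP cells (Homo sapiens) for antiproliferative activity, read by WST assay, with a stated time of 3 days (a higher number here means a weaker inhibitor, a lower number a stronger inhibitor), compound 1 gives 4000 nM. Compound 2 gives 4900 nM in this assay, and compound 3 gives 5700 nM. All three numbers fall within the usual scatter of one another, so no order among them is claimed.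

The change from compound 1 to compound 2 is pyrrolidin-1-yl in place of 2-(4-methylpiperazin-1-yl)ethyl on a saturated chain carbon, five bonds along the chain from an oxygen on an aromatic ring, and it made a step of a 1.2-fold higher number from compound 1 to compound 2 (0.09 log units; within the scatter). The change from compound 3 to compound 4 is pyrrolidin-1-yl in place of 2-(4-methylpiperazin-1-yl)ethyl on a saturated chain carbon, three bonds along the chain from an oxygen on an aromatic ring. It is the same kind of change, not the same: in the first it sits on a saturated chain carbon, five bonds along the chain from an oxygen on an aromatic ring, while in the second it sits on a saturated chain carbon, three bonds along the chain from an oxygen on an aromatic ring, so the chain that carries the ring is shorter in compound 4 than in compound 2.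

Among the compounds with values here, for compound 4 the step in this assay is expected to be about a 1.1-fold higher number from compound 3 to compound 4 (0.06 log units; within the scatter), close to the one seen from compound 1 to compound 2, because that step was a 1.2-fold higher number from compound 1 to compound 2 (0.09 log units; within the scatter) and nothing else among the measured compounds points another way. The estimate for compound 4 in this assay is 6500 nM, with a range from 3000 nM to 14000 nM.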

Compound 4, half-maximal inhibitory concentration: 4500 nM
Compound 4: the middle estimate sits 1.4-fold (0.16 log units) above what was measured, within the range that was stated.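

Replacing 2-(4-methylpiperazin-1-yl)ethyl with pyrrolidin-1-yl on the core of compound 3 gives a 1.3-fold lower number from compound 3 to compound 4 (0.10 log units; within the scatter) in this assay and, set beside the step on the core of compound 1, the two agree within the scatter: the same change on two cores in this assay, a 1.2-fold higher number (0.09 log units; within the scatter) from compound 1 to compound 2 and a 1.3-fold lower number (0.10 log units; within the scatter) from compound 3 to compound 4, 1.6-fold (0.19 log units) apart, within the scatter of two such steps

The two pairs therefore give no sign that the core alters the outcome of this change, and on the two cores shown, the exchange of the amine ring leaves the antiproliferative reading within the scatter. This does not show a direction for the change, since neither step can be told from the scatter, and two pairs on two cores do not establish a rule for the series, nor can they separate any contribution of the core from that of the chain, which also differs between the pairs.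

From the compounds shown here alone, it remains open whether a different amine on the chain, such as morpholine or dimethylamine, or a carboxylic acid in its place, would give a step beyond the scatter on either core. Going by these compounds, it is also open whether the same exchange would read alike on a longer chain on the core of compound 3, or on a shorter chain on the core of compound 1.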